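Methoxy on the Phenyl of a Non-Cytotoxic Thienopyridine Amide

The source may report more compounds than this note shows. Statements on the series, on what has been measured and on what is new or still open speak of the compounds shown alone.

Compound 1 `NC(=O)c1sc2nc(-c3ccccc3)cc(C(F)(F)F)c2c1N` stands only at a limit in an ADME assay on Huh-7 cells (Homo sapiens) for cytotoxicity, read by MTT assay, with a stated time of 72 h; a lower number here means that less compound is tolerated, a higher number that more compound is tolerated: compound 1 gives > 20000 nM, which is a limit of the assay rather than a measured number. Its close relative compound 2 `CN(C)C(=O)c1sc2nc(-c3ccccc3)cc(C(F)(F)F)c2c1N` carries a dimethylamino in place of amino on the carbonyl carbon, and in this assay compound 2 gives > 20000 nM, again a limit. The step that the two limits leave unreadable from compound 1 to compound 2 therefore cannot be read, and the limit of > 20000 nM in this assay, at which 2 of the 2 values shown sit, is all the measured evidence shows. Compound 3 `COc1ccc(-c2cc(C(F)(F)F)c3c(N)c(C(N)=O)sc3n2)cc1` differs from compound 1 by methoxy in place of hydrogen on an aromatic carbon. No measured step touches this methoxy change, so nothing shown points to a shift in either direction beyond the scatter. He expects compound 3 to sit at the limit as well, an estimated 30000 nM within 15000 nM to 80000 nM. The expected step is a step that the limit leaves unreadable from compound 1 to compound 3, most likely reported only as a limit.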

Compound 3, half-maximal cytotoxic concentration: 46400 nM
Estimate against measurement, compound 3: 1.5-fold (0.19 log units) below, within the range that was stated.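

Compound 3 gives a measured number while compound 1 stands only at a limit, so the step between compound 1 and compound 3 cannot be read. On these data alone, what stays open is whether methoxy in place of hydrogen shifts the result in this assay at all.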